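Hydrazone aryl replacement on the compound 1 core

The source may hold more compounds than are shown below. What is called first, only, known or untested is meant among the compounds shown, and "the series" means these compounds.

Compound 1 `CCCSc1nc(N/N=C/c2ccccc2F)c2nnn(Cc3ccccc3)c2n1` carries a 2-fluorophenyl on a carbon with a double bond to nitrogen. In a functional assay on MGC-803 cells (Homo sapiens) for antiproliferative activity, read by MTT assay, with a stated time of 72 h (a higher number here means a weaker inhibitor, a lower number a stronger inhibitor), compound 1 gives only a limit, > 64000 nM, and no number; this is the limit (the limit of > 64000 nM in this assay, at which 1 of the 3 values shown sits). Compound 3 `CCCSc1nc(N/N=C/c2ccc([N+](=O)[O-])cc2)c2nnn(Cc3ccccc3)c2n1` differs from compound 1 in one place, 4-nitrophenyl in place of 2-fluorophenyl on a carbon with a double bond to nitrogen, and in this assay compound 3 gives 10100 nM; the step is an at least 6.3-fold lower number from compound 1 to compound 3 (0.80 log units; beyond the scatter). Compound 2 `CCCSc1nc(N/N=C(\C)c2ccccc2O)c2nnn(Cc3ccccc3Cl)c2n1` is not a single-place neighbour of compound 1; in this assay compound 2 gives 35000 nM. Compound 4 `CCCSc1nc(N/N=C(\C)c2ccc(Br)cc2)c2nnn(Cc3ccccc3)c2n1` has not been measured. It differs from compound 1 as follows: a group of 10 heavy atoms (8 carbon, 1 nitrogen, 1 bromine; one six-membered aromatic ring of carbon only) in place of a group of 9 heavy atoms (7 carbon, 1 nitrogen, 1 fluorine; one six-membered aromatic ring of carbon only), on a nitrogen on an aromatic ring. Going by the values given here, the only measured step that bears on this change is the one from compound 1 to compound 3, which moved the number downward beyond the scatter, though with a limit at its start. A step in the same direction, of uncertain size, is expected here; the step from compound 1 to compound 4 is estimated as an at least 2.9-fold lower number from compound 1 to compound 4 (0.46 log units; beyond the scatter). In this assay compound 4 is expected at about 22000 nM, within a range from 7000 nM to 64000 nM.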

Compound 4, half-maximal inhibitory concentration: 6020 nM
Compound 4: middle estimate off by 3.7-fold (0.56 log units), on the high side; measured number below the stated range.
By their numbers in this assay, from the lowest: compounds 4 and 3 (each within the scatter of the next); then compound 2. At a limit, above all of these: compound 1.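

Hydrazone aryl replacement, reading of compound 4: at the place on a nitrogen on an aromatic ring, the entering group of 10 heavy atoms, with its bromine, gives an at least 10-fold lower number from compound 1 to compound 4 (1.02 log units; beyond the scatter) in this assay. This is a second replacement at this place that lowers the number beyond the scatter, so the earlier step with 4-nitrophenyl no longer stands alone, and the two replaced compounds read closely: compound 3 gives 10100 nM and compound 4 gives 6020 nM, within the scatter of each other. The true size of the step stays unread because compound 1 gives only a limit and no number: the limit of > 64000 nM in this assay, at which 1 of the 4 values shown sits.

The entering group differs from the leaving group by both its bromine and an added carbon, and the compounds shown do not separate the share of each in the step. On these data alone, whether an amine or a carboxylic acid on the same aromatic ring would keep the number in this range, or a longer chain on the sulfur of the shared core would move it, stays open.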